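Benzylic substituent changes on the shared core: compound 4 outlook

The compounds below may be only part of what the source reports. "The series", "measured", "known", "first", "only" and "open" are said of these compounds alone.

Measured compounds in an assay on isolated protein for binding affinity to melanin-concentrating hormone receptor 1 (Homo sapiens); on this read-out higher numbers stand for weaker inhibition and lower numbers for stronger inhibition:
- compound 1, `CN1CCN(CCCN(c2nc3cc(F)c(F)cc3[nH]2)[C@@H]2CC[C@]3(c4cccc(C#N)c4)C[C@@H]3C2)CC1`: 8.4 nM
- compound 2, `CN1CCN(CCCN(c2nc3cc(F)c(F)cc3[nH]2)[C@@H]2CC[C@]3(c4cccc(C=O)c4)C[C@@H]3C2)CC1`: 16.3 nM
- compound 3, `CN1CCN(CCCN(c2nc3cc(F)c(F)cc3[nH]2)[C@@H]2CC[C@]3(c4cccc(CO)c4)C[C@@H]3C2)CC1`: 70.8 nM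

Compound 3 gives the highest number of the three in this assay; it lies beyond the scatter from both others, see a 4.3-fold higher number from compound 2 to compound 3 (0.64 log units; beyond the scatter) and an 8.4-fold higher number from compound 1 to compound 3 (0.93 log units; beyond the scatter). Between compound 1 and compound 2 the step is a 1.9-fold higher number from compound 1 to compound 2 (0.29 log units; within the scatter) and stays within the scatter.

Compound 4, `CN1CCN(CCCN(c2nc3cc(F)c(F)cc3[nH]2)[C@@H]2CC[C@]3(c4cccc(CN5CCCC5)c4)C[C@@H]3C2)CC1`, differs from compound 3 by pyrrolidin-1-yl in place of hydroxy on a saturated chain carbon bound to an aromatic carbon. Among the measured compounds shown here, none of the measured steps covers this kind of exchange: all three measured compounds vary the group on the aromatic carbon among cyano, formyl and hydroxymethyl, and no amine appears among them. What the measured steps do show is that this position moves the number by modest amounts, as in an 8.4-fold higher number from compound 1 to compound 3 (0.93 log units; beyond the scatter) and a 4.3-fold higher number from compound 2 to compound 3 (0.64 log units; beyond the scatter). Compound 3 also sits at the weak end, so a return toward compound 1 or compound 2 is a plausible outcome, but without a direct precedent the uncertainty is wide. Compound 4 is therefore expected to show a step of a 2.0-fold lower number from compound 3 to compound 4 (0.31 log units; beyond the scatter), uncertain in direction. The estimate for compound 4 in this assay is 35 nM, with a range from 8 nM to 150 nM.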

Compound 4, inhibition constant: 25.7 nM
The estimate for compound 4 lay 1.4-fold (0.13 log units) above the measured number, within the range that was stated.
By their numbers in this assay, from the lowest: compounds 1, 2 and 4 (each within the scatter of the next, the first and the last beyond it); then compound 3.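

In this assay, the first amine at this place in the compounds shown brings the number down from the hydroxymethyl level, with pyrrolidin-1-yl in place of hydroxy giving a 2.8-fold lower number from compound 3 to compound 4 (0.44 log units; beyond the scatter). This position therefore accepts a (pyrrolidin-1-yl)methyl group, which has a five-membered ring and no hydrogen-bond donor: a 1.6-fold higher number from compound 2 to compound 4 (0.20 log units; within the scatter) stays within the scatter of the formyl compound, while a 3.1-fold higher number from compound 1 to compound 4 (0.49 log units; beyond the scatter) remains beyond the scatter of the cyano compound. No supporting data are available to explain these shifts.

The compounds shown do not separate the contribution of the pyrrolidine ring from that of its nitrogen. Going by these compounds, how the number responds to (dimethylamino)methyl, (morpholin-4-yl)methyl or a carboxylic acid on the same aromatic carbon remains open.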